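The compounds below may be only part of what the source reports. "The series", "measured", "known", "first", "only" and "open" are said of these compounds alone.

Compound 3 `COc1ccc(-c2nc(SC)nc(NCCCCNc3ccnc4cc(Cl)ccc34)c2C#N)cc1` carries a 4-methoxyphenyl on the shared core and gives 20000 nM in an ADME assay on MDCK cells (Canis lupus familiaris) for cytotoxicity, read by microscopy; on this read-out higher numbers stand for lower toxicity in this test and lower numbers for higher toxicity in this test. It sits level with compound 1 `CSc1nc(NCCCCNc2ccnc3cc(Cl)ccc23)c(C#N)c(-c2cccc([N+](=O)[O-])c2)n1`, which in this assay gives 20000 nM, the two together being the highest numbers of the three; the step of no change at the digits printed from compound 1 to compound 3 (within the scatter) is within the scatter. Among the compounds with values here, compound 2 `CSc1nc(NCCCCNc2ccnc3cc(Cl)ccc23)c(C#N)c(-c2ccc([N+](=O)[O-])cc2)n1`, with the 4-nitrophenyl, gives 4000 nM, so that a 5.0-fold lower number from compound 1 to compound 2 (0.70 log units; beyond the scatter) and a 5.0-fold higher number from compound 2 to compound 3 (0.70 log units; beyond the scatter) are the only steps beyond the scatter.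

Compound 4 `COc1ccc(-c2nc(SC)nc(NCCCCNc3ccnc4cc(Cl)ccc34)c2C#N)cc1OC` differs from compound 3 by methoxy in place of hydrogen on an aromatic carbon, read one bond further out as 4-methoxyphenyl to 3,4-dimethoxyphenyl. Within the data shown here, no measured step adds a second group to this ring; the steps that bear on it show that exchanging nitro for methoxy on the ring, as in a 5.0-fold higher number from compound 2 to compound 3 (0.70 log units; beyond the scatter), raised the number, while moving a group around the ring, as in a 5.0-fold lower number from compound 1 to compound 2 (0.70 log units; beyond the scatter), lowered it. Adding a methoxy next to an existing methoxy is expected to leave the number close to that of compound 3, as no change at the digits printed from compound 3 to compound 4 (within the scatter). Compound 4 is therefore estimated at 20000 nM, with a range of 8000 nM to 40000 nM.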

Compound 4, minimum cytotoxic concentration: 20000 nM
Estimate against measurement, compound 4: no gap at the digits printed, and the stated range covers the measured number.
By their numbers in this assay, from the lowest: compound 2; then compounds 1, 3 and 4 (each within the scatter of the next).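

In this assay, within the data shown here, the added methoxy, ortho to a methoxy group, reads as no change at the digits printed from compound 3 to compound 4 (within the scatter) and is the first step that puts a second group on this ring, so this position takes a methoxy without a shift in the number. The 3,4-dimethoxyphenyl reads as no change at the digits printed from compound 1 to compound 4 (within the scatter) against the 3-nitrophenyl and as a 5.0-fold higher number from compound 2 to compound 4 (0.70 log units; beyond the scatter) against the 4-nitrophenyl, which leaves the 4-nitrophenyl as the only ring here set apart from the others. No measurement at hand gives a reason for these readings.

On these data alone, whether an amine, a carboxylic acid or a longer alkoxy chain at this position would also leave the number in place stays open. Also open, as far as these compounds go, is whether a methoxy here reads the same with nitro in place of the existing methoxy.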